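Swapping a chlorophenyl for a difluorophenyl on the thioethyl chain

The source may report more compounds than this note shows. Statements on the series, on what has been measured and on what is new or still open speak of the compounds shown alone.

Compound 2 `C#CCNC1CCc2c(SCCc3cccc(Cl)c3)cccc21` gives the higher of the two numbers measured in an assay on isolated protein for inhibition of Amine oxidase [flavin-containing] B (Homo sapiens) (on this read-out lower numbers stand for stronger inhibition and higher numbers for weaker inhibition), namely 82400 nM; compound 1 `C#CCNC1CCc2c(SCCc3ccc(C)cc3)cccc21` gives 25800 nM. Going by the values given here, the only measured step, a 3.2-fold higher number from compound 1 to compound 2 (0.50 log units; beyond the scatter), shows that exchanging the aryl group on this chain shifts the number by a modest amount. Compound 3 `C#CCNC1CCc2c(SCCc3ccc(F)c(F)c3)cccc21` carries the change (3,4-difluorophenyl in place of 3-chlorophenyl on a saturated chain carbon, two bonds along the chain from a sulfur), for which no direct comparison exists among the measured compounds. Among the compounds with values here, because the single measured exchange a 3.2-fold higher number from compound 1 to compound 2 (0.50 log units; beyond the scatter) was modest, compound 3 is expected to stay near compound 2, with a step of a 1.4-fold lower number from compound 2 to compound 3 (0.14 log units; within the scatter) in this assay that may not exceed the scatter. Compound 3 is therefore estimated at 60000 nM in this assay, within a range from 20000 nM to 180000 nM.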

Compound 3, half-maximal inhibitory concentration: 3240 nM
Beside the measured number, compound 3's estimate is 19-fold (1.27 log units) above it; the whole stated range lies above it.
By their numbers in this assay, from the lowest: compound 3; then compound 1; then compound 2.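

In this assay the aryl group on this chain matters more than the first pair suggested: a 25-fold lower number from compound 2 to compound 3 (1.41 log units; beyond the scatter) is a large step, and an 8.0-fold lower number from compound 1 to compound 3 (0.90 log units; beyond the scatter) is modest but also beyond the scatter. Both steps put the 3,4-difluorophenyl of compound 3 at the lowest number of the three compounds, so this position responds strongly to which substituted phenyl it carries, and the two earlier compounds showed only a small part of that range. Nothing at hand accounts for the size of this change.

Still open, going by these compounds, is whether a single fluorine, as in 4-fluorophenyl or 3-fluorophenyl, would lower the number as far as the 3,4-difluorophenyl does. Also open, on these data alone, is how a longer chain carrying the 3,4-difluorophenyl, or an amine on that phenyl ring, would read in this assay.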